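A few compounds are considered here, and "the series" means these few. Any claim that something is new, unique, unknown or untested is made for them only; others in the source may bear on it.

Compound 1, with the structure `O=C1/C(=C/c2cccnc2)CN(S(=O)(=O)c2ccc(Br)cc2)C/C1=C\c1ccccc1C(F)(F)F`, gives 5760 nM in a functional assay on SMMC-7721 cells (Homo sapiens) for cytotoxicity, read by MTT assay, with a stated time of 24 h; on this read-out higher numbers stand for weaker inhibition and lower numbers for stronger inhibition. Compound 2, with the structure `N#Cc1ccc(S(=O)(=O)N2C/C(=C\c3cccnc3)C(=O)/C(=C/c3ccccc3C(F)(F)F)C2)cc1`, carries cyano in place of bromo on an aromatic carbon relative to compound 1, and in this assay compound 2 gives 9650 nM, so that a 1.7-fold higher number from compound 1 to compound 2 (0.22 log units; within the scatter). Compound 3, with the structure `O=C1/C(=C/c2ccncc2)CN(S(=O)(=O)c2ccc(Br)cc2)C/C1=C\c1ccccc1C(F)(F)F`, differs from compound 1 by pyridin-4-yl in place of pyridin-3-yl on a double-bonded chain carbon bound to a double-bonded ring carbon, and in this assay compound 3 gives 10500 nM, giving a 1.8-fold higher number from compound 1 to compound 3 (0.26 log units; within the scatter). Going by the values given here, compound 4, with the structure `N#Cc1ccc(S(=O)(=O)N2C/C(=C\c3ccncc3)C(=O)/C(=C/c3ccccc3C(F)(F)F)C2)cc1`, has not been measured; it differs from compound 3 by cyano in place of bromo on an aromatic carbon, which is the same change as the one seen from compound 1 to compound 2, made at the same place on the shared core. Among the compounds with values here, because that earlier step was a 1.7-fold higher number from compound 1 to compound 2 (0.22 log units; within the scatter), the step from compound 3 to compound 4 is expected to be of similar size, namely a 1.5-fold higher number from compound 3 to compound 4 (0.18 log units; within the scatter), though with only one prior example the expectation rests on a narrow base. Compound 4 is therefore estimated to give 16000 nM in this assay, with a likely range from 7000 nM to 36000 nM.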

Compound 4, half-maximal inhibitory concentration: 9610 nM
Beside the measured number, compound 4's estimate is 1.7-fold (0.22 log units) above it; the measured number falls inside the stated range.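

Cyano in place of bromo gives a 1.1-fold lower number from compound 3 to compound 4 (0.04 log units; within the scatter) in this assay, and this step does not differ measurably from the same change on the core of compound 1: the same change on two cores in this assay, a 1.7-fold higher number (0.22 log units; within the scatter) from compound 1 to compound 2 and a 1.1-fold lower number (0.04 log units; within the scatter) from compound 3 to compound 4, 1.8-fold (0.26 log units) apart, within the scatter of two such steps

Pyridin-4-yl in place of pyridin-3-yl gives a 1.0-fold lower number from compound 2 to compound 4 (0.00 log units; within the scatter), and here too the two steps do not differ measurably: the same change on two cores in this assay, a 1.8-fold higher number (0.26 log units; within the scatter) from compound 1 to compound 3 and a 1.0-fold lower number (0.00 log units; within the scatter) from compound 2 to compound 4, 1.8-fold (0.26 log units) apart, within the scatter of two such steps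

Going by these compounds alone, each change therefore carries from one core to the other without a detectable difference, but all of these steps lie within the scatter, so this shows only that neither change moved the number measurably on these cores; it does not show that a real shift would carry over in the same way, and each comparison rests on a single pair of steps.

From the compounds shown here alone, whether an amine or a carboxylic acid in place of bromo and cyano would give a step beyond the scatter remains open. So does the outcome with pyridin-2-yl, or with a group other than trifluoromethyl, which all four compounds share.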